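Replacing Trifluoromethyl with Methoxy on the Shared Core

The source may hold more compounds than are shown below. What is called first, only, known or untested is meant among the compounds shown, and "the series" means these compounds.

Measured so far in an ADME assay on MDBK cells (Bos taurus) for cytotoxicity, read by MTT assay, with a stated time of 96 h; a higher number here means that more compound is tolerated, a lower number that less compound is tolerated:
- Compound 1 `C/C(=N\NC(N)=S)c1ccc2[nH]c(-c3ccc(Cl)cc3)nc2c1` gives > 100000 nM as a limit of the assay
- Compound 2 `C/C(=N\NC(N)=S)c1ccc2[nH]c(-c3ccc(C(F)(F)F)cc3)nc2c1` gives 5000 nM as a true number

Among the measured compounds shown here, compound 2 holds the only true number in this small set (5000 nM) and so serves as the starting point. The reading for compound 1 (> 100000 nM) is a limit, not a number. For the measured compounds named here, the one measured step is an at least 20-fold lower number from compound 1 to compound 2 (1.30 log units; beyond the scatter), with trifluoromethyl in place of chloro on an aromatic carbon.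

Compound 3 `COc1ccc(-c2nc3cc(/C(C)=N/NC(N)=S)ccc3[nH]2)cc1` keeps the shared core and changes that same carbon, with methoxy in place of trifluoromethyl on an aromatic carbon. Methoxy itself has not been measured here, so the earlier step is only an indirect guide. A move back towards higher numbers is expected since an at least 20-fold lower number from compound 1 to compound 2 (1.30 log units; beyond the scatter) came with the arrival of trifluoromethyl, the group now leaving. The expected change is a 5.0-fold higher number from compound 2 to compound 3 (0.70 log units; beyond the scatter), a clear but uncertain rise. Compound 3 is estimated at 25000 nM, within an expected range from 6000 nM to 100000 nM in this assay.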

Compound 3, half-maximal cytotoxic concentration: 13000 nM
Compound 3: middle estimate off by 1.9-fold (0.28 log units), on the high side; the range from low to high includes it.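

In this assay, putting methoxy in place of trifluoromethyl on this aromatic carbon gives a 2.6-fold higher number from compound 2 to compound 3 (0.41 log units; beyond the scatter), so part of the drop seen with compound 2 is recovered, but not all of it. Putting methoxy in place of chloro gives an at least 7.6-fold lower number from compound 1 to compound 3 (0.88 log units; beyond the scatter), which places compound 3 between the other two and shows that the three groups at this one position give three separate levels, not just a well-tolerated group and a poorly tolerated one. The reading for compound 1 is a limit, not a number, so any step from it gives only a bound: the limit of > 100000 nM in this assay, at which 1 of the 3 values shown sits.

Among the compounds shown here, with only three groups, the data cannot show whether group size or the hydrogen-bond acceptor that enters with methoxy is what moves the number. As far as these compounds go, how a hydroxyl, an amine, a carboxylic acid or a longer chain such as ethoxy on the same carbon would fall against these three levels also stays open.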